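A few compounds are considered here, and "the series" means these few. Any claim that something is new, unique, unknown or untested is made for them only; others in the source may bear on it.

Compounds measured in an assay (Equus caballus) for inhibition of Thromboxane-A synthase (Homo sapiens), using microsomes; on this read-out higher numbers stand for weaker inhibition and lower numbers for stronger inhibition:
compound 1 `CC(C)(O)C(CCC/C=C(\c1ccccc1)c1cccnc1)C(=O)O`: 42 nM
compound 2 `COC(=O)CCCC/C=C(\c1ccccc1)c1cccnc1`: 100 nM

Going by the values given here, on these two numbers compound 2 stands highest, the only measured step being a 2.4-fold higher number from compound 1 to compound 2 (0.38 log units; beyond the scatter). Compound 3 `CCOC(=O)CCCC/C=C(\c1ccccc1)c1cccnc1` differs from compound 2 by methyl in place of hydrogen on a saturated chain carbon bound to an oxygen next to a carbonyl group. Among the compounds with values here, no measured step bears on this change; the one step known, from compound 1 to compound 2, concerns the other end of the chain, so nothing in the data points either way. The expected step is therefore none beyond the scatter, no change at the digits printed from compound 2 to compound 3 (within the scatter). For compound 3 in this assay the estimate is 100 nM, with a range from 40 nM to 250 nM.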

Compound 3, half-maximal inhibitory concentration: 600 nM
Beside the measured number, compound 3's estimate is 6.0-fold (0.78 log units) below it; the measured number lies above the stated range.
By their numbers in this assay, from the lowest: compound 1; then compound 2; then compound 3.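

In this assay, the end of the ester proves sensitive to a very small change: methyl in place of hydrogen on the saturated chain carbon bound to an oxygen next to a carbonyl group, turning methoxycarbonyl into ethoxycarbonyl, gives a 6.0-fold higher number from compound 2 to compound 3 (0.78 log units; beyond the scatter). With ethoxycarbonyl, the distance to the 1-carboxy-2-hydroxy-2-methylpropyl compound grows to a 14-fold higher number from compound 1 to compound 3 (1.15 log units; beyond the scatter). No available evidence bears on the reason for this step. Still open, on these data alone, is how a longer chain on the ester oxygen, such as propyl or butyl, or a free carboxylic acid at this chain end would read.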